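This account rests on a few compounds, and the source may have more. Where it says the series, first, only, none or still open, it means among the compounds named here.

Of the compounds shown here, three sharing one core have so far been measured in an assay on mitochondria for inhibition of HSP60/HSP10 (Homo sapiens); a lower number here means a stronger inhibitor, a higher number a weaker inhibitor. Compound 1 `O=S(=O)(Nc1ccc(-c2nc3cc(NS(=O)(=O)c4ccc(C(F)(F)F)cc4)ccc3o2)cc1)c1ccc(C(F)(F)F)cc1` gives 57000 nM in this assay. Compound 2 `COc1ccc(S(=O)(=O)Nc2ccc3oc(-c4ccc(NC(=O)c5ccc(Cl)s5)cc4)nc3c2)cc1` gives 61000 nM. Compound 3 `COc1ccc(S(=O)(=O)Nc2ccc3oc(-c4ccc(NS(=O)(=O)c5cc(Br)ccc5OC)cc4)nc3c2)cc1` gives 67000 nM; its number is the highest of the three shown, yet its gaps to compound 2 and to compound 1 both lie within the scatter. Among the measured compounds shown here, the one single-point step among them is a 1.1-fold higher number from compound 2 to compound 3 (0.04 log units; within the scatter).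

Compound 4 `COc1ccc(S(=O)(=O)Nc2ccc3oc(-c4ccc(NC(=O)C5CCN(C(C)=O)CC5)cc4)nc3c2)cc1` has not yet been measured in this assay. It differs from compound 3 at one place: (1-acetylpiperidin-4-yl)carbonyl in place of (5-bromo-2-methoxyphenyl)sulfonyl on a nitrogen on an aromatic ring. The step from compound 2 to compound 3 bears on this, as it also exchanged the group on that same nitrogen, a carbonyl for a sulfonyl, and stayed within the scatter. The present change brings back a carbonyl, now carried by a six-membered non-aromatic ring. No step beyond the scatter is therefore expected. For compound 4 the expected step is a 1.1-fold lower number from compound 3 to compound 4 (0.05 log units; within the scatter). Compound 4 is estimated at 60000 nM, with a range from 25000 nM to 150000 nM.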

Compound 4, half-maximal inhibitory concentration: 24000 nM
Compound 4: middle estimate off by 2.5-fold (0.40 log units), on the high side, and the stated range ends above it.
By their numbers in this assay, from the lowest: compound 4; then compounds 1, 2 and 3 (each within the scatter of the next).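

In this assay, the group on this nitrogen on an aromatic ring now shifts the number beyond the scatter, with a 2.8-fold lower number from compound 3 to compound 4 (0.45 log units; beyond the scatter) and a 2.5-fold lower number from compound 2 to compound 4 (0.41 log units; beyond the scatter), whereas the earlier exchange at this place, a 1.1-fold higher number from compound 2 to compound 3 (0.04 log units; within the scatter), did not. The carbonyl on the nitrogen is shared by compound 2 and compound 4, so in that pair the change lies in the group on the carbonyl carbon, where 1-acetylpiperidin-4-yl replaces 5-chlorothiophen-2-yl. No information is available on the reason for this modest shift.

The compounds shown leave open whether the acetyl on the piperidine nitrogen matters, which a free secondary amine or a methanesulfonyl group there would test. Going by these compounds, it also remains open whether a smaller non-aromatic ring, such as cyclopropyl, on the carbonyl would serve as well.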